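The source may hold more compounds than are shown below. What is called first, only, known or untested is meant among the compounds shown, and "the series" means these compounds.

Compound 1 `O=C(COc1cccc2ccccc12)N/N=C/c1ccc(Cl)cc1`: 4.54
Compound 2 `O=C(COc1cccc2ccccc12)N/N=C/c1cccc(Br)c1`: 4.81
Compound 3 `O=C(COc1cccc2ccccc12)N/N=C/c1ccc(Br)cc1`: 4.81

In a physicochemical assay for lipophilicity, measured as octanol-water partition (on this read-out lower numbers stand for lower lipophilicity and higher numbers for higher lipophilicity), compound 3 stands level with compound 2, and together they are the highest of the three numbers; the step of a number 0.27 log units higher from compound 1 to compound 3 (within the scatter) and the step of no change at the digits printed from compound 2 to compound 3 (within the scatter) both lie within the scatter. Compound 4 `COc1ccc(/C=N/NC(=O)COc2cccc3ccccc23)cc1` differs from compound 3 by methoxy in place of bromo on an aromatic carbon. Going by the values given here, none of the measured steps bears directly on this change: they exchange bromo for chloro, or a 4-bromophenyl for a 3-bromophenyl, and all of them stay within the scatter. Among the compounds with values here, the measured data therefore offer no step to copy. For compound 4 a lower number than compound 3 is expected in this assay, a step of a number 0.91 log units lower from compound 3 to compound 4 (beyond the scatter). The estimate for compound 4 is 3.9, with a range from 3.5 to 4.3.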

Compound 4, partition coefficient: 3.77
Estimate against measurement, compound 4: 0.13 log units above; measured number inside the range.
By their numbers in this assay, from the lowest: compound 4; then compounds 1, 2 and 3 (each within the scatter of the next).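

In this assay, the aromatic carbon carrying the halogen now shows a change beyond the scatter: methoxy in place of bromo gives (a number 1.04 log units lower from compound 3 to compound 4 (beyond the scatter)), and methoxy in place of chloro gives (a number 0.77 log units lower from compound 1 to compound 4 (beyond the scatter)). The 4-methoxyphenyl in place of the 3-bromophenyl gives (a number 1.04 log units lower from compound 2 to compound 4 (beyond the scatter)), so compound 4 stands apart from all three halogen compounds, whose own steps stayed within the scatter. Nothing measured here explains this difference. From the compounds shown here alone, whether an amine or a carboxylic acid on this aromatic carbon would fall with methoxy or stay with bromo and chloro remains open.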